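The source may report more compounds than this note shows. Statements on the series, on what has been measured and on what is new or still open speak of the compounds shown alone.

In a toxicity assay on THP-1 cells (Homo sapiens) for inhibition (on this read-out higher numbers stand for lower toxicity in this test and lower numbers for higher toxicity in this test), compound 1 (`COc1ccc(-c2cnc(NC(=O)c3ccc(F)cc3)n2Cc2ccccc2)cc1`) gives > 100000 nM as a limit and not a number. Compound 2 (`COc1ccc(-c2cnc(NC(=O)c3ncc[nH]3)n2C)cc1`) gives > 100000 nM as a limit too. Compound 3 (`COc1ccc(-c2cnc(NC(=O)C3CCNCC3)n2C)cc1`) gives > 100000 nM as a limit as well. Among the measured compounds shown here, the only measured step is a step that the two limits leave unreadable from compound 2 to compound 3 and it offers no size to carry over. Compound 4 (`COc1ccc(-c2cnc(NC(=O)c3ccc(F)cc3)n2-c2ccccc2)cc1`) has phenyl in place of benzyl on an aromatic nitrogen. No step beyond the scatter is expected in this assay because the limit of > 100000 nM in this assay, at which 3 of the 3 values shown sit, is all the series shows, compound 1 included. The expected change is a number no higher from compound 1 to compound 4 (the limit leaves the size open) with no direction foreseen. Compound 4 is estimated at 100000 nM with an expected range from 50000 nM to 200000 nM and will probably be reported only as a limit.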

Compound 4, half-maximal cytotoxic concentration: 8800 nM
Beside the measured number, compound 4's estimate is 11-fold (1.06 log units) above it, outside the stated range (below it).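

In this assay, among the compounds shown here, the group on the aromatic nitrogen is the first place where a change gives a readable step: phenyl in place of benzyl brings an at least 11-fold lower number from compound 1 to compound 4 (1.05 log units; beyond the scatter). The direction is towards higher toxicity in this test, and compound 4 alone gives a number instead of a limit: the limit of > 100000 nM in this assay, at which 3 of the 4 values shown sit.

Open, going by these compounds, is what a longer chain, such as phenethyl, or an amine on the phenyl ring would give on this nitrogen. Also open, on these data alone, is whether phenyl gives a similar step with the piperidin-4-yl group of compound 3 or the 1H-imidazol-2-yl group of compound 2.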